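Replacing piperazin-1-yl in compound 3

The source may hold more compounds than are shown below. What is called first, only, known or untested is meant among the compounds shown, and "the series" means these compounds.

In a functional assay on V79 cells (Cricetulus griseus) for cytotoxicity, read by colony formation (a higher number here means a weaker inhibitor, a lower number a stronger inhibitor), compound 3 (`O=C(O)c1cn(C2CC2)c2c(C(F)(F)F)c(N3CCNCC3)c(F)cc2c1=O`) gives 1650 ug/mL, the highest number among the measured compounds. Compound 2 (`CCNCC1CCN(c2c(F)cc3c(=O)c(C(=O)O)cn(C4CC4)c3c2C(F)(F)F)C1`) gives 120 ug/mL. Compound 4 (`CC1(N)CCN(c2c(F)cc3c(=O)c(C(=O)O)cn(C4CC4)c3c2C(F)(F)F)C1`) carries 3-amino-3-methylpyrrolidin-1-yl in place of piperazin-1-yl on an aromatic carbon, ortho to a fluoro group and ortho to a trifluoromethyl group: 3-amino-3-methylpyrrolidin-1-yl in place of piperazin-1-yl on an aromatic carbon. Within the data shown here, the one measured step that bears on this change is large: a 14-fold higher number from compound 2 to compound 3 (1.14 log units; beyond the scatter), with piperazin-1-yl replacing 3-((ethylamino)methyl)pyrrolidin-1-yl. Compound 4 reverses that kind of exchange, so a large step to a lower number is expected in this assay. The structurally closest compound is compound 1 (`NC1CCN(c2c(F)cc3c(=O)c(C(=O)O)cn(C4CC4)c3c2C(F)(F)F)C1`), at 300 ug/mL; 300 ug/mL; 300 ug/mL (3 entries). The expected step is a 5.9-fold lower number from compound 3 to compound 4 (0.77 log units; beyond the scatter). For compound 4 the estimated value is 280 ug/mL, with an expected range of 110 ug/mL to 700 ug/mL.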

Compound 4, half-maximal inhibitory concentration: 110 ug/mL
Beside the measured number, compound 4's estimate is 2.5-fold (0.41 log units) above it, within the range that was stated.
By their numbers in this assay, from the lowest: compounds 4 and 2 (each within the scatter of the next); then compound 3.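

In this assay, the exchange of piperazin-1-yl for 3-amino-3-methylpyrrolidin-1-yl at this aromatic carbon now has its own large step (a 15-fold lower number from compound 3 to compound 4 (1.18 log units; beyond the scatter)), so the high number of compound 3 no longer stands against compound 2 alone. The two pyrrolidin-1-yl substituents of compound 2 and compound 4 stay level (a 1.1-fold lower number from compound 2 to compound 4 (0.04 log units; within the scatter)), although their side groups differ. No measurement here accounts for either step. Still open, from the compounds shown here alone, is whether morpholin-4-yl, with a ring oxygen in place of the ring amine, would stand with compound 3 or with compound 2 and compound 4.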